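Linker exchange on the shared core of compound 2

This account rests on a few compounds, and the source may have more. Where it says the series, first, only, none or still open, it means among the compounds named here.

The series is followed in an assay on isolated protein for agonist activity at Bile acid receptor (Homo sapiens), read by FRET; on this read-out lower numbers stand for an effect already at smaller amounts and higher numbers for an effect only at larger amounts of compound. Compound 1 `CC(C)c1onc(-c2c(Cl)cccc2Cl)c1COc1ccc(N(C)Cc2cccc(C(=O)O)c2)c(C(F)(F)F)n1` gives 12 nM in this assay, and compound 2 `CN(Cc1cccc(C(=O)O)c1)c1ccc(OCc2c(-c3c(Cl)cccc3Cl)noc2C2CC2)nc1C(F)(F)F` gives 3 nM. For the measured compounds named here, the only single-point step recorded so far is a 4.0-fold lower number from compound 1 to compound 2 (0.60 log units; beyond the scatter). Compound 2 therefore stands at the lowest of the two numbers, with compound 1 the nearest at a higher value.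

Compound 3 `O=C(O)c1cccc(OCc2ccc(OCc3c(-c4c(Cl)cccc4Cl)noc3C3CC3)nc2C(F)(F)F)c1` keeps the cyclopropyl that distinguishes compound 2 and alters a different place: (3-carboxyphenoxy)methyl in place of (3-carboxybenzyl)(methyl)amino on an aromatic carbon. Going by the values given here, no measured step touches this part of the shared core; the one known step concerns the group on the isoxazole side, so it offers no direct guide to the present exchange. With only this indirect support, a change of modest size is expected in this assay, with a somewhat weaker outcome held a little more likely than a stronger one, and the step of a 2.7-fold higher number from compound 2 to compound 3 (0.43 log units; beyond the scatter) is taken as the expectation. Compound 3 is accordingly estimated at 8 nM in this assay, within a range of 2 nM to 40 nM.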

Compound 3, half-maximal effective concentration: 43 nM
Compound 3: the middle estimate sits 5.4-fold (0.73 log units) below what was measured, and the stated range ends below it.
By their numbers in this assay, from the lowest: compound 2; then compound 1; then compound 3.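

In this assay, the exchange on the aromatic carbon ortho to a trifluoromethyl group gives a 14-fold higher number from compound 2 to compound 3 (1.16 log units; beyond the scatter), showing that this position, untouched by the earlier pair, can shift the number substantially. The step is large, whereas the exchange of isopropyl for cyclopropyl, a 4.0-fold lower number from compound 1 to compound 2 (0.60 log units; beyond the scatter), is modest. The leaving (3-carboxybenzyl)(methyl)amino and the entering (3-carboxyphenoxy)methyl both hold a six-membered aromatic ring of carbon only and have matching counts of hydrogen-bond donors and acceptors, yet they differ in the nitrogen, which the entering group lacks, and in having one heavy atom fewer, so the matching counts do not carry over to a matching result; nothing measured here accounts for the loss.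

The exchange alters the chain's atoms and its length together, so the compounds shown leave open which of these differences matters. On these data alone, a secondary amine without the methyl, or an amide at this place, would help separate them, and it also remains open whether the step would have the same size with isopropyl in place of cyclopropyl.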